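Adding a Methoxy Group to the Phenyl Chain

This account rests on a few compounds, and the source may have more. Where it says the series, first, only, none or still open, it means among the compounds named here.

For the measured compounds named here, compound 2 `O=C(CCc1ccccc1)Nc1nc2ccccc2c(=O)s1` is the stronger of the two compounds measured so far. In an assay on mitochondria (strain Sprague-Dawley) for inhibition of Amine oxidase [flavin-containing] B (Rattus norvegicus), read by fluorescence and Amplex Red, with stated times of 30 min and 45 min (a lower number here means a stronger inhibitor, a higher number a weaker inhibitor), compound 2 gives 42.7 nM. Compound 1 `O=C(CCCc1ccccc1)Nc1nc2ccsc2c(=O)s1` differs from compound 2 in several places. In this assay compound 1 gives 298 nM, a number that lies beyond the usual scatter above that of compound 2. Compound 3 `COc1cccc(CCC(=O)Nc2nc3ccccc3c(=O)s2)c1` has not been measured yet. It differs from compound 2 in a single place: methoxy in place of hydrogen on an aromatic carbon; the methoxy sits on an aromatic carbon of a six-membered aromatic ring of carbon only, meta to a large group. Going by the values given here, no measured pair shows what such a change does, so the expectation rests on compound 2 alone. The step from compound 2 to compound 3 is expected to be small, within the scatter in either direction: a 1.1-fold higher number from compound 2 to compound 3 (0.02 log units; within the scatter). Compound 3 is therefore estimated at 45 nM in this assay, within a range from 15 nM to 140 nM.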

Compound 3, half-maximal inhibitory concentration: 621 nM
Beside the measured number, compound 3's estimate is 14-fold (1.14 log units) below it; measured number above the stated range.
By their numbers in this assay, from the lowest: compound 2; then compound 1; then compound 3.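

For the compounds shown here, this is the first step that changes only one place, since compound 1 differs from compound 2 in several. In this assay, going from phenyl to 3-methoxyphenyl brings a 15-fold higher number from compound 2 to compound 3 (1.16 log units; beyond the scatter), so this aromatic ring does not accept every addition at this position without a large loss of strength. The data at hand give no measurement that accounts for this step.

From the compounds shown here alone, it remains open whether the loss belongs to methoxy itself or to any group placed here, a question that a smaller group such as fluorine or methyl, or a hydroxyl, could help answer. Going by these compounds, it is also open whether methoxy at another carbon of the ring, or on a longer chain, would give a similar step.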